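The compounds below may be only part of what the source reports. "The series", "measured", "known", "first", "only" and "open" are said of these compounds alone.

Working notes on the series, read in a functional assay on K562 cells (Homo sapiens) for inhibition, read by CCK-8 assay, with a stated time of 72 h; on this read-out higher numbers stand for weaker inhibition and lower numbers for stronger inhibition. Compound 1 `Cc1cccc(NS(=O)(=O)c2cccc(CCCCCCNC(=O)/C=C/c3cccnc3)c2)c1` gives 4.78 nM. Compound 2 `Cc1ccc(C)c(NS(=O)(=O)c2cccc(CCCCCCNC(=O)/C=C/c3cccnc3)c2)c1` gives 0.84 nM. Compound 3 `O=C(/C=C/c1cccnc1)NCCCCCCc1cccc(S(=O)(=O)Nc2ccc(Cl)cc2)c1` gives 6.41 nM.

Compound 3 stands level with compound 1, the measured move being a 1.3-fold higher number from compound 1 to compound 3 (0.13 log units; within the scatter). Compound 2 stands apart from both, with a 5.7-fold lower number from compound 1 to compound 2 (0.76 log units; beyond the scatter) and a 7.6-fold higher number from compound 2 to compound 3 (0.88 log units; beyond the scatter).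

Compound 4 `O=C(/C=C/c1cccnc1)NCCCCCCc1cccc(S(=O)(=O)Nc2ccc(F)cc2)c1` comes from compound 3 through fluoro in place of chloro on an aromatic carbon, para to a large group. Among the measured compounds shown here, no measured step exchanges one halogen for another, so the evidence is indirect. The only large moves seen so far involve the dimethyl pattern of compound 2, as in a 7.6-fold higher number from compound 2 to compound 3 (0.88 log units; beyond the scatter). The closest comparison to a change of a single substituent on the sulfonamide aryl group is a 1.3-fold higher number from compound 1 to compound 3 (0.13 log units; within the scatter), and it stays within the scatter. On that basis no step beyond the scatter is expected in this assay. The estimated move is a 1.2-fold lower number from compound 3 to compound 4 (0.07 log units; within the scatter). For compound 4 the expected value is 5.5 nM, with an estimated range of 2.2 nM to 14 nM.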

Compound 4, half-maximal inhibitory concentration: 0.93 nM
Estimate against measurement, compound 4: 5.9-fold (0.77 log units) above; the measured number lies below the stated range.
By their numbers in this assay, from the lowest: compounds 2 and 4 (each within the scatter of the next); then compounds 1 and 3 (each within the scatter of the next).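

In this assay the halogen at this place on the ring, para to a large group, proves to matter: there is a 6.9-fold lower number from compound 3 to compound 4 (0.84 log units; beyond the scatter) for a change of one atom, whereas the earlier swap of 3-methylphenyl for 4-chlorophenyl stayed within the scatter. A single fluoro also reaches the level of the 2,5-dimethylphenyl compound, with a 1.1-fold higher number from compound 2 to compound 4 (0.04 log units; within the scatter) and with a 5.1-fold lower number from compound 1 to compound 4 (0.71 log units; beyond the scatter) as well, so the two methyl groups are not the only route to the lower numbers in this small set. Nothing at hand accounts for the gap between fluoro and chloro at this place.

From the compounds shown here alone, whether bromo, methoxy or an unsubstituted phenyl would sit with compound 4 or with compound 3 remains open. Also open, going by these compounds, is whether fluoro keeps this standing in the presence of a methyl group on the same ring or with a longer chain.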